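A few compounds are considered here, and "the series" means these few. Any claim that something is new, unique, unknown or untested is made for them only; others in the source may bear on it.

Compound 1 `Cn1cc(-c2cnc(NCc3c(F)ccc4c3CCO4)c3cn[nH]c(=O)c23)cn1`, compound 2 `O=C1CCCN1c1cnc(NCc2c(F)ccc3c2CCO3)n2cnnc12` and compound 3 `Cc1nc(C(=O)N(C)C)ccc1-c1cnc(NCc2c(F)ccc3c2CCO3)c2cn[nH]c(=O)c12` were all measured in an ADME assay on microsomes from liver (Homo sapiens) for metabolic stability, read by LC-MS, using NADPH, with stated times of 5 min and 30 min, tested at 1 uM; on this read-out lower numbers stand for slow clearance and higher numbers for fast clearance. In this assay compound 1 gives 21 mL.min-1.g-1. Compound 3 gives 19 mL.min-1.g-1 in this assay. For compound 2 this assay reports only a limit, < 3 mL.min-1.g-1, and no number. Compound 2 is therefore the one of the three that sits on (the limit of < 3 mL.min-1.g-1 in this assay, at which 1 of the 3 values shown sits), while compound 1 and compound 3 return numbers well clear of that limit.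

Compound 4 `C[C@H]1CC(=O)N(c2cnc(NCc3c(F)ccc4c3CCO4)n3cnnc23)C1` is compound 2 with a single change: methyl in place of hydrogen on a saturated ring carbon. Cut one bond further out, the change reads 2-oxopyrrolidin-1-yl to 4-methyl-2-oxopyrrolidin-1-yl, the new group standing two ring bonds from the ring nitrogen and two ring bonds from the ring atom that bears the large group. Going by the values given here, no measured pair among the three compounds shows a change of this kind, so there is no measured step to lean on. The account expects the step from compound 2 to compound 4 to be small, an at least 1.3-fold higher number from compound 2 to compound 4 (0.12 log units; that floor lies within the scatter), upward if anything and not clearly beyond the scatter. Compound 4 is thus expected to read about 4 mL.min-1.g-1 in this assay, between 1.5 mL.min-1.g-1 and 12 mL.min-1.g-1, with a real chance that the assay again reports only a limit.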

Compound 4, intrinsic clearance in microsomes: < 3 mL.min-1.g-1
Compound 4: a limit, no number; the forecaster's own chance of this, stated with the estimate: 40%; middle value at least 1.3-fold (0.12 log units) away from the limit.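

In this assay, going by these compounds alone, compound 2 and compound 4 both return only a limit and no number, so no step between them can be read: the limit of < 3 mL.min-1.g-1 in this assay, at which 2 of the 4 values shown sit. The compounds shown leave open whether methyl in place of hydrogen on a saturated ring carbon changes the clearance at all, in either direction, beneath that limit.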